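Cyano on the benzyl ring of a chromone ether

The compounds below may be only part of what the source reports. "The series", "measured", "known", "first", "only" and "open" are said of these compounds alone.

Measured compounds:
compound 1 `O=c1ccoc2cc(OCc3cn(Cc4ccccc4)nn3)ccc12` gives 42900 nM in a functional assay on SW480 cells (Homo sapiens) for cytotoxicity, read by MTT assay, with a stated time of 48 h; a higher number here means a weaker inhibitor, a lower number a stronger inhibitor
compound 2 `O=c1ccoc2cc(OCc3cn(Cc4cccc(Br)c4)nn3)ccc12` gives > 100000 nM in this assay, a limit of the assay
compound 3 `N#Cc1ccc(Cn2cc(COc3ccc4c(=O)ccoc4c3)nn2)cc1` gives > 100000 nM in this assay, a limit of the assay

Within the data shown here, compound 1 holds the only number in this assay; the other two values are limits, as noted in the limit of > 100000 nM in this assay, at which 2 of the 3 values shown sit. Compound 4 `N#Cc1cccc(Cn2cc(COc3ccc4c(=O)ccoc4c3)nn2)c1` differs from compound 1 by cyano in place of hydrogen on an aromatic carbon. Among the measured compounds shown here, two measured steps bear on it: an at least 2.3-fold higher number from compound 1 to compound 2 (0.36 log units; beyond the scatter), and an at least 2.3-fold higher number from compound 1 to compound 3 (0.36 log units; beyond the scatter). Both substitutions on the benzyl ring weaken inhibition at least modestly, and the cyano group of compound 4 sits on the same ring. Compound 4 is therefore expected to show a 2.6-fold higher number from compound 1 to compound 4 (0.41 log units; beyond the scatter), most likely ending at the assay limit. The estimate for compound 4 is 110000 nM, with a range from 45000 nM to 300000 nM.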

Compound 4, half-maximal inhibitory concentration: > 100000 nM
Compound 4: no number, only a limit (the forecaster's own chance of this, stated with the estimate: 70%); the middle value does not contradict the limit.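

In this assay, moving the nitrile to the 3-cyanophenyl group still weakens inhibition, with an at least 2.3-fold higher number from compound 1 to compound 4 (0.36 log units; beyond the scatter). The loss seen with the 4-cyanophenyl group of compound 3 is therefore not confined to that one placement of the cyano group. The steps among compound 2, compound 3 and compound 4 cannot be read, and how these three compounds differ stays hidden at the limit: the limit of > 100000 nM in this assay, at which 3 of the 4 values shown sit.

As far as these compounds go, whether an amine or a carboxylic acid on the benzyl ring would give a lower number than compound 1 remains open. So does the effect of a longer chain between the triazole and the phenyl ring.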